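The source may report more compounds than this note shows. Statements on the series, on what has been measured and on what is new or still open speak of the compounds shown alone.

Compound 3 `N#CCn1c(=N)sc2cc(OC(F)(F)F)ccc21` carries a cyanomethyl chain on the aromatic nitrogen of the shared core. In a functional assay on the whole organism with Rattus norvegicus as the target (on this read-out lower numbers stand for an effect already at smaller amounts and higher numbers for an effect only at larger amounts of compound), compound 3 gives 3.5 mg/kg, the lower of the two numbers shown so far. The nearest number belongs to compound 2 `Nc1nc2ccc(SC(F)(F)F)cc2s1`, which in this assay gives 8 mg/kg, a gap beyond the scatter. Compound 1 `Nc1nc2ccc(I)cc2s1` gives > 10 mg/kg in this assay, which is a limit of the assay and not a number (the limit of > 10 mg/kg in this assay, at which 1 of the 3 values shown sits). Among the compounds with values here, the one step between measured compounds, an at least 1.2-fold lower number from compound 1 to compound 2 (0.09 log units; that floor lies within the scatter), concerns an exchange on an aromatic carbon of the core.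

Compound 4 `CSCCCn1c(=N)sc2cc(OC(F)(F)F)ccc21` differs from compound 3 on the chain bound to the aromatic nitrogen: 2-(methylsulfanyl)ethyl in place of cyano on a saturated chain carbon bound to an aromatic nitrogen. Within the data shown here, no measured step touches this chain, and the step on the aromatic carbon carries no information over to it. The expectation is therefore a step of no more than the usual scatter, in either direction; the estimated step is no change at the digits printed from compound 3 to compound 4 (within the scatter). Compound 4 is expected to give 3.5 mg/kg in this assay, with a range from 1.5 mg/kg to 8 mg/kg.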

Compound 4, dose for half-maximal effect: 4.2 mg/kg
Compound 4: middle estimate off by 1.2-fold (0.08 log units), on the low side; measured number inside the range.
By their numbers in this assay, from the lowest: compounds 3, 4 and 2 (each within the scatter of the next, the first and the last beyond it). At a limit, above all of these: compound 1.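

The chain on the aromatic nitrogen accepts a clear exchange in this assay: cyanomethyl gives way to 3-(methylsulfanyl)propyl with no change beyond the scatter (a 1.2-fold higher number from compound 3 to compound 4 (0.08 log units; within the scatter)). Within the data shown here, this is the first measured step at this position, and it shows that, in this pair, the nitrile is not needed to keep a number of this size, with a thioether chain serving as well. Nothing in the data shown bears on a cause for this outcome.

Open, from the compounds shown here alone, is whether an amine or a carboxylic acid at the end of this chain would keep the number in the same range. Also open, going by these compounds, is whether the 3-(methylsulfanyl)propyl chain behaves alike when the aromatic carbon carries iodo or (trifluoromethyl)sulfanyl.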